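The source may report more compounds than this note shows. Statements on the series, on what has been measured and on what is new or still open speak of the compounds shown alone.

Compound 1 `Cc1ccccc1C(=O)N[C@@H](C(=O)N1CCC(c2ccc(Cl)cc2)CC1)C(C)C`: 32 nM
Compound 2 `Cc1cccc(CCC(=O)N[C@@H](C(=O)N2CCC(c3ccc(Cl)cc3)CC2)C(C)C)c1`: 22 nM

In an assay on THP-1 cells for displacement of a labelled ligand from C-C chemokine receptor type 1 (Homo sapiens) (a higher number here means a weaker inhibitor, a lower number a stronger inhibitor), compound 1 gives 32 nM, the highest of the two numbers, and its nearest neighbour compound 2 gives 22 nM, a gap within the scatter. Among the measured compounds shown here, the only measured step, a 1.5-fold lower number from compound 1 to compound 2 (0.16 log units; within the scatter), changes the acyl group and leaves the stereocentre untouched, so it does not bear directly on the present change. Compound 3 `Cc1ccccc1C(=O)NC(C(=O)N1CCC(c2ccc(Cl)cc2)CC1)C(C)C` differs from compound 1 in that (the two compounds have the same atoms and bonds; at least one stereo element is drawn with a configuration in one of them and without one in the other: 1 of 1 stereo elements differ; a stereocentre at a saturated chain carbon is drawn R in compound 1 and without a configuration in compound 3). Compound 3 may therefore contain either the drawn form alone or a mixture of both forms. Compound 3 is expected to give 50 nM (range 20 nM to 160 nM), with the step of a 1.6-fold higher number from compound 1 to compound 3 (0.19 log units; within the scatter) expected to lie near the scatter.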

Compound 3, half-maximal inhibitory concentration: 36 nM
Estimate against measurement, compound 3: 1.4-fold (0.14 log units) above; low and high end bracket the measured number.
By their numbers in this assay, from the lowest: compounds 2, 1 and 3 (each within the scatter of the next).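

In this assay, the stereocentre at the saturated chain carbon, drawn R in compound 1 and without a configuration in compound 3, comes with a 1.1-fold higher number from compound 1 to compound 3 (0.05 log units; within the scatter). Compound 3 may be the drawn form alone or a mixture of both forms, so its number says little about the other form by itself. The comparison rests on one fact about the drawings: the fact that one of compounds 1 and 3 is drawn with a defined configuration and the other without, at the place where they differ

As far as these compounds go, how the opposite form alone behaves remains open. So does how a carboxylic acid on the acyl group would fare in this assay.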